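From a Butyl to a Methylphenyl Sulfonyl Group

This account rests on a few compounds, and the source may have more. Where it says the series, first, only, none or still open, it means among the compounds named here.

Of the compounds shown here, three have been measured in a functional assay on RH7777 cells for antagonist activity at lysophosphatidic acid receptor 2 (Homo sapiens), read by calcium flux; a lower number here means a stronger inhibitor, a higher number a weaker inhibitor. Compound 1 `Cc1ccccc1N1CCN(C[C@H](C)Nc2nc(C(F)(F)F)nc3ccccc23)CC1` gives 730 nM. Compound 2 `Cc1csc2c(N[C@@H](C)CN3CCN(S(=O)(=O)c4ccc(Cl)c(Cl)c4)CC3)ncnc12`, which carries a 3,4-dichlorophenyl on its sulfonyl sulfur, gives 17 nM. Compound 3 `CCCCS(=O)(=O)N1CCN(C[C@H](C)Nc2ncnc3c(C)csc23)CC1`, the same core with a butyl on that sulfur, gives 6610 nM and so has the highest number of the three, meaning it is the weakest inhibitor among them.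

Compound 4 `Cc1cccc(S(=O)(=O)N2CCN(C[C@H](C)Nc3ncnc4c(C)csc34)CC2)c1` is compound 3 with one change: 3-methylphenyl in place of butyl on a sulfonyl sulfur. Among the compounds with values here, one measured step bears directly on this change: a 390-fold higher number from compound 2 to compound 3 (2.59 log units; beyond the scatter). That step shows how strongly this assay responds when the group on the sulfonyl sulfur is switched between an aromatic ring and a short chain. Compound 4 reverses that switch in kind, putting a six-membered aromatic ring back on the sulfur, although with a single methyl rather than two chlorines, so a full return to the number of compound 2 is not assured. A large downward step is nevertheless expected: a 55-fold lower number from compound 3 to compound 4 (1.74 log units; beyond the scatter). Compound 4 is therefore estimated at 120 nM, with a plausible range from 30 nM to 500 nM.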

Compound 4, half-maximal inhibitory concentration: 310 nM
The estimate for compound 4 lay 2.6-fold (0.41 log units) below the measured number; the range from low to high includes it.
By their numbers in this assay, from the lowest: compound 2; then compound 4; then compound 1; then compound 3.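

Putting a ring back on the sulfonyl sulfur brings a large gain even without any chlorine: in this assay there is a 21-fold lower number from compound 3 to compound 4 (1.33 log units; beyond the scatter) when 3-methylphenyl replaces butyl. The earlier step between the butyl and 3,4-dichlorophenyl compounds changed the chain to a ring and added two chlorines all at once, so it could not show how much the ring alone contributes. Compound 4 separates these parts, since there is still an 18-fold higher number from compound 2 to compound 4 (1.26 log units; beyond the scatter) on going to 3-methylphenyl from 3,4-dichlorophenyl, so what is attached to the ring matters as well as the ring itself, though no measurement here explains either step.

The compounds shown leave open how much of the remaining gap depends on losing the methyl and how much on gaining the chlorines, a question that a plain phenyl or a phenyl with a single chlorine would help to settle. As far as these compounds go, it is also open whether a ring is truly needed on the sulfur, or whether a longer chain such as octyl, or a benzyl, could match the aromatic groups.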